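From 3,4-dihydroxyphenyl to 2,4-dihydroxyphenyl

The source may hold more compounds than are shown below. What is called first, only, known or untested is meant among the compounds shown, and "the series" means these compounds.

In an ADME assay on MDCK cells (Canis lupus familiaris) for cytotoxicity (a lower number here means that less compound is tolerated, a higher number that more compound is tolerated), compound 1 `O=[N+]([O-])C1=CNc2nc(-c3ccco3)nn2C1` gives 108000 nM, and compound 2 `O=[N+]([O-])C1=CNc2ncnn2C1c1ccc(O)c(O)c1` gives 368000 nM. Compound 3 `O=[N+]([O-])C1=CNc2nc(-c3ccco3)nn2C1c1ccc(O)c(O)c1` gives > 1200000 nM, which is a limit of the assay and not a number. Compound 4 `O=[N+]([O-])C1=CNc2nc(-c3ccco3)nn2C1c1ccc(O)cc1O` differs from it by one swap 2,4-dihydroxyphenyl in place of 3,4-dihydroxyphenyl on a saturated ring carbon. Within the data shown here, two measured steps bear on this. Adding the 3,4-dihydroxyphenyl group gave a large step of an at least 11-fold higher number from compound 1 to compound 3 (1.04 log units; beyond the scatter), and adding furan-2-yl gave an at least modest one an at least 3.2-fold higher number from compound 2 to compound 3 (0.51 log units; beyond the scatter). Both added a group, whereas this swap keeps the same atoms, so no clear direction is expected. The expected step of an at least 1.2-fold lower number from compound 3 to compound 4 (0.07 log units; that floor lies within the scatter) does not go beyond the scatter. For compound 4 the estimated value is 1000000 nM, within an expected range of 400000 nM to 2000000 nM.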

Compound 4, half-maximal cytotoxic concentration: 119000 nM
Compound 4: middle estimate off by 8.4-fold (0.92 log units), on the high side, outside the stated range (below it).
By their numbers in this assay, from the lowest: compounds 1 and 4 (each within the scatter of the next); then compound 2. At a limit, above all of these: compound 3.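

At this saturated ring carbon, where the two hydroxy groups sit on the phenyl ring counts, and not just the presence of the ring: in this assay the swap gives an at least 10-fold lower number from compound 3 to compound 4 (1.00 log units; beyond the scatter). Putting 2,4-dihydroxyphenyl in place of hydrogen gives a 1.1-fold higher number from compound 1 to compound 4 (0.04 log units; within the scatter), so this isomer, unlike 3,4-dihydroxyphenyl, leaves the number within the scatter. Compound 3 sits at a limit of the assay, so the first step is only a floor: the limit of > 1200000 nM in this assay, at which 1 of the 4 values shown sits.

As far as these compounds go, whether a methoxy group or an amine on this phenyl ring would follow either isomer remains open. So does whether the swap has the same effect without furan-2-yl.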